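This account rests on a few compounds, and the source may have more. Where it says the series, first, only, none or still open, it means among the compounds named here.

Measured so far in a functional assay on HeLa cells (Homo sapiens) for antiproliferative activity, with a stated time of 24 h; a lower number here means a stronger inhibitor, a higher number a weaker inhibitor:
compound 1 `Cc1ccc(C(=O)Nc2sc3c(c2C(N)=O)CCN(Cc2c(Cl)cccc2Cl)C3)cc1`, 47400 nM
compound 2 `NC(=O)c1c(NC(=O)c2cccc([N+](=O)[O-])c2)sc2c1CCN(Cc1c(Cl)cccc1Cl)C2`, 46100 nM
compound 3 `Cc1ccc(C(=O)Nc2sc3c(c2C(N)=O)CCN(C(=S)Nc2ccccc2Cl)C3)cc1`, 26300 nM

Compound 2 differs from compound 1 by 3-nitrophenyl in place of 4-methylphenyl on a carbonyl carbon; that change made a 1.0-fold lower number from compound 1 to compound 2 (0.01 log units; within the scatter). Compound 3 differs from compound 1 by a group of 10 heavy atoms (7 carbon, 1 nitrogen, 1 sulfur, 1 chlorine; one six-membered aromatic ring of carbon only) in place of a group of 9 heavy atoms (7 carbon, 2 chlorine; one six-membered aromatic ring of carbon only), on an amine nitrogen in a ring, so the two cores in this set differ by that group on the ring nitrogen. Compound 4 `NC(=O)c1c(NC(=O)c2cccc([N+](=O)[O-])c2)sc2c1CCN(C(=S)Nc1ccccc1Cl)C2` has not yet been measured. It differs from compound 3 by 3-nitrophenyl in place of 4-methylphenyl on a carbonyl carbon, which is the same change as from compound 1 to compound 2, at the same place. Compound 4 is expected to sit close to compound 3, because a 1.0-fold lower number from compound 1 to compound 2 (0.01 log units; within the scatter) shows this change left the number essentially unchanged on the core of compound 1. The expected step is a 1.0-fold lower number from compound 3 to compound 4 (0.01 log units; within the scatter). In this assay compound 4 is therefore estimated at 25500 nM, probably between 12000 nM and 55000 nM.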

Compound 4, half-maximal inhibitory concentration: 40300 nM
For compound 4 the middle estimate is 1.6-fold (0.20 log units) below the measured one; measured number inside the range.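

In this assay, 3-nitrophenyl in place of 4-methylphenyl on the carbonyl carbon gives a 1.5-fold higher number from compound 3 to compound 4 (0.19 log units; within the scatter) on the second core, and this agrees with the first core: the same change on two cores in this assay, a 1.0-fold lower number (0.01 log units; within the scatter) from compound 1 to compound 2 and a 1.5-fold higher number (0.19 log units; within the scatter) from compound 3 to compound 4, 1.6-fold (0.20 log units) apart, within the scatter of two such steps. The change on the ring nitrogen gives a 1.1-fold lower number from compound 2 to compound 4 (0.06 log units; within the scatter) when the 3-nitrophenyl group is present, and it also agrees with the step seen with 4-methylphenyl: the same change on two cores in this assay, a 1.8-fold lower number (0.26 log units; within the scatter) from compound 1 to compound 3 and a 1.1-fold lower number (0.06 log units; within the scatter) from compound 2 to compound 4, 1.6-fold (0.20 log units) apart, within the scatter of two such steps. Neither change moved the number beyond the scatter, so the agreement shows only that both stayed small on these cores, not that a large effect would carry over from one core to another.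

As far as these compounds go, it remains open whether a different group on the carbonyl carbon, such as a pyridine ring or a short alkyl chain, would shift the number beyond the scatter. From the compounds shown here alone, it also remains open whether such a shift would carry over between these two cores.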